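The source may report more compounds than this note shows. Statements on the series, on what has been measured and on what is new or still open speak of the compounds shown alone.

Measured in an ADME assay on HEK293 cells (Homo sapiens) for cytotoxicity, read by MTT assay, with a stated time of 48 h; a higher number here means a weaker inhibitor, a lower number a stronger inhibitor:
- Compound 1 `CCS(=O)(=O)Nc1ccc(NC(=O)c2ccc(Cl)cc2)cc1C` gives 125000 nM
- Compound 2 `CCS(=O)(=O)Nc1ccc(NC(=O)c2ccc(C#N)cc2)cc1C` gives > 250000 nM (a limit)
- Compound 3 `Cc1cc(NC(=O)c2ccc(C#N)cc2)ccc1NS(=O)(=O)C(F)(F)F` gives > 250000 nM (a limit)

Compound 2 stands at > 250000 nM, which is a limit of the assay and not a number. Compound 4 `CCS(=O)(=O)Nc1ccc(NC(=O)c2ccc(C#N)cc2)cc1F` differs from it in one place: fluoro in place of methyl on an aromatic carbon. Neither measured step touches that methyl. They are an at least 2.0-fold higher number from compound 1 to compound 2 (0.30 log units; that floor lies within the scatter), and a step that the two limits leave unreadable from compound 2 to compound 3. Little can be read from them because of the limit of > 250000 nM in this assay, at which 2 of the 3 values shown sit. With no measured sign of a large change, the expected result is a number no higher from compound 2 to compound 4 (the limit leaves the size open), so no step beyond the scatter is expected in this assay. Compound 4 is expected near 250000 nM, with an estimated range from 120000 nM to 500000 nM.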

Compound 4, half-maximal inhibitory concentration: 26400 nM
Estimate against measurement, compound 4: 9.5-fold (0.98 log units) above; measured number outside the range, below it.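

The earlier compounds shown here changed only the group on the other aromatic ring and the chain on the sulfonyl sulfur, leaving this position untouched. In this assay, fluoro in place of methyl ortho to the (ethylsulfonyl)amino group gives an at least 9.4-fold lower number from compound 2 to compound 4 (0.97 log units; beyond the scatter). Exchanging this single heavy atom is thus enough to yield a measurable number from compound 2, whose value is a limit.

From the compounds shown here alone, the true size of the step stays unread because of a limit: the limit of > 250000 nM in this assay, at which 2 of the 4 values shown sit. Whether a methoxy or an amino group at this position would lower the number as well remains open.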